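The compounds below may be only part of what the source reports. "The series", "measured", "known", "first", "only" and "open" are said of these compounds alone.

Series notes. Three measured compounds share one core and vary the group on the oxygen next to a carbonyl group. Compound 1 `CCCCc1nc(C(C)C)c(CC(=O)OC2CC2)c(=O)n1Cc1ccc(-c2ccccc2-c2noc(=O)[nH]2)cc1` carries cyclopropyl there; in an ADME assay on microsomes from liver (Homo sapiens) for metabolic stability, with a stated time of 30 min (a higher number here means that more of the compound is left, a lower number that less of the compound is left), compound 1 gives 10.3%. Compound 2 `CC#CCOC(=O)Cc1c(C(C)C)nc(CCCC)n(Cc2ccc(-c3ccccc3-c3noc(=O)[nH]3)cc2)c1=O` carries but-2-yn-1-yl in that place; in this assay compound 2 gives 13.7%. The step of a number 3.4 percentage points higher from compound 1 to compound 2 (within the scatter) is within the scatter. For the measured compounds named here, compound 3 `CCCCc1nc(C)c(CC(=O)OC(C)C)c(=O)n1Cc1ccc(-c2ccccc2-c2noc(=O)[nH]2)cc1` carries isopropyl on that oxygen and differs from compound 1 and compound 2 in a second place as well, so no single counted step leads to it; in this assay compound 3 gives 17.5%. The number of compound 3 sits within the usual scatter of the numbers of compound 2 and compound 1, so no order among the three can be read from these data.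

Compound 4 `CCCCc1nc(C)c(CC(=O)OCC2CC2)c(=O)n1Cc1ccc(-c2ccccc2-c2noc(=O)[nH]2)cc1` is not yet measured. Its change from compound 3 is cyclopropylmethyl in place of isopropyl on an oxygen next to a carbonyl group. Going by the values given here, the only counted step at this position is a number 3.4 percentage points higher from compound 1 to compound 2 (within the scatter), and it stayed within the scatter; a swap of one small ester group for another has not yet moved the read-out. The expected step of a number 1.5 percentage points lower from compound 3 to compound 4 (within the scatter) is therefore none beyond the scatter. For compound 4 in this assay the estimate is 16%, expected to fall between 7% and 27%.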

Compound 4, percent of the compound remaining: 20%
For compound 4 the middle estimate is 4 percentage points below the measured one; low and high end bracket the measured number.
By their numbers in this assay, from the lowest: compounds 1, 2, 3 and 4 (each within the scatter of the next).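

Cyclopropylmethyl in place of isopropyl on an oxygen next to a carbonyl group gives a number 2.5 percentage points higher from compound 3 to compound 4 (within the scatter) in this assay and brings in the first counted step that adds a three-membered non-aromatic ring and takes the group from 3 to 4 heavy atoms, all carbon. For the compounds shown here, it is also the first counted step at this position on the core of compound 3, whereas the earlier one stood on the core of compound 1, so both cores now show a swap at this oxygen that stays within the scatter, including one that adds a ring where none stood. No measurement at hand bears on what lies behind this read-out.

All the groups shown on this oxygen are built of carbon only, so it remains open whether a longer chain, an ether chain or an amine there, or the free carboxylic acid in place of the ester, would move the read-out beyond the scatter. The compounds shown also offer no single step for the second place in which the two cores differ, so its contribution to this assay cannot be read.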